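Thiazolidine amides with an octadecyl chain: aryl substituent change

This account rests on a few compounds, and the source may have more. Where it says the series, first, only, none or still open, it means among the compounds named here.

Two members of the series have numbers in a functional assay on PPC-1 cells (Homo sapiens) for antiproliferative activity, read by sulforhodamine B assay (a lower number here means a stronger inhibitor, a higher number a weaker inhibitor), so far. Compound 1 `CCCCCCCCCCCCCCCCCCNC(=O)[C@H]1CSC(C2CCCCC2)N1` carries a cyclohexyl group on the saturated ring carbon; in this assay compound 1 gives 9300 nM. Compound 2 `CCCCCCCCCCCCCCCCCCNC(=O)[C@H]1CSC(c2cccnc2)N1` carries pyridin-3-yl at the same position; in this assay compound 2 gives 2900 nM. Among the measured compounds shown here, the one measured step, a 3.2-fold lower number from compound 1 to compound 2 (0.51 log units; beyond the scatter), shows the pyridin-3-yl compound with the lower number, and compound 2 therefore stands lowest of the two numbers, with compound 1 as its only neighbour.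

Compound 3 `CCCCCCCCCCCCCCCCCCNC(=O)[C@H]1CSC(c2ccc(F)c(Br)c2)N1` is not yet measured. It differs from compound 2 as follows: 3-bromo-4-fluorophenyl in place of pyridin-3-yl on a saturated ring carbon. For the measured compounds named here, no measured step compares two aromatic groups at this position, so the only bearing step is the cyclohexyl-to-pyridin-3-yl change, which was modest. An aromatic ring remains in place, so a number near that of compound 2 is expected, with a step of a 1.3-fold lower number from compound 2 to compound 3 (0.12 log units; within the scatter) that is not expected to exceed the scatter by much. For compound 3 in this assay an estimate of 2200 nM is made, with a range from 700 nM to 7000 nM.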

Compound 3, half-maximal inhibitory concentration: 4700 nM
Beside the measured number, compound 3's estimate is 2.1-fold (0.33 log units) below it; low and high end bracket the measured number.
By their numbers in this assay, from the lowest: compounds 2, 3 and 1 (each within the scatter of the next, the first and the last beyond it).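

Replacing pyridin-3-yl with 3-bromo-4-fluorophenyl on this saturated ring carbon gives a 1.6-fold higher number from compound 2 to compound 3 (0.21 log units; within the scatter) in this assay, so the pyridine ring nitrogen, the one hydrogen-bond acceptor in the leaving group, can give way to a carbon-only aromatic ring carrying two halogens without a step beyond the scatter. Among the compounds shown here, the second new step, a 2.0-fold lower number from compound 1 to compound 3 (0.30 log units; within the scatter), also stays within the scatter, so the separation seen between cyclohexyl and pyridin-3-yl does not carry over to this aromatic group, and compound 2 remains the only compound here whose number is separated from that of compound 1. No measurement available here accounts for these numbers.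

The compounds shown leave open whether plain phenyl, or a phenyl ring carrying only the bromine or only the fluorine, would fall with compound 2 or compound 3. They also leave open how a pyridin-2-yl or pyridin-4-yl group, or a ring bearing an amine or a carboxylic acid, would read at this carbon with the octadecyl chain kept in place.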